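This account rests on a few compounds, and the source may have more. Where it says the series, first, only, none or still open, it means among the compounds named here.

Measured so far in an in vivo ADME assay on the whole organism (Canis lupus familiaris) for pharmacokinetics; a lower number here means slower removal, a higher number faster removal of the compound:
- compound 1 `CC(C)c1ncc([C@@H](CCCCCCc2ccc3c(n2)NCCC3)CC(=O)O)cn1`: "not determined" (no result reported)
- compound 2 `O=C(O)C[C@H](CCCCCCc1ccc2c(n1)NCCC2)c1cnc2ccccc2c1`: 3 mL/min/kg

Compound 1 has no number to stand on: in this assay compound 1 is recorded as "not determined" (no result reported). The only figure in this small set therefore belongs to compound 2, which gives 3 mL/min/kg.

The next compound to be tested is compound 3 `COc1ncc([C@@H](CCCCCCc2ccc3c(n2)NCCC3)CC(=O)O)cn1`. It keeps the core of compound 1 and changes one group: methoxy in place of isopropyl on an aromatic carbon. In words, methoxy takes the place of isopropyl on an aromatic carbon, so that 2-isopropylpyrimidin-5-yl becomes 2-methoxypyrimidin-5-yl.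

For the measured compounds named here, no measured pair shows what such a change does. The expectation is therefore no step beyond the scatter in this assay, with the low figure of compound 2 at 3 mL/min/kg as the only anchor. For compound 3 the estimated clearance is 4 mL/min/kg, with an expected range of 1.5 mL/min/kg to 12 mL/min/kg.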

Compound 3, clearance in the Canis lupus familiaris assay: 4.3 mL/min/kg
Compound 3: middle estimate off by 1.1-fold (0.03 log units), on the low side; measured number inside the range.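

In the Canis lupus familiaris assay, 2-methoxypyrimidin-5-yl in place of quinolin-3-yl on the saturated chain carbon gives a 1.4-fold higher number from compound 2 to compound 3 (0.16 log units; within the scatter), so clearance does not separate these two aromatic groups. The step from isopropyl to methoxy on the pyrimidine cannot be read for clearance, since compound 1 offers no number to set against compound 3. The same change does register in a physicochemical assay for lipophilicity (on this read-out higher numbers stand for higher lipophilicity and lower numbers for lower lipophilicity), where compound 1 gives 1.32 and compound 3 gives 0.65. Compound 3 thus sits clearly apart from compound 1: the measured partition coefficient of compound 1, 1.32, and of compound 3, 0.65, a number 0.67 log units lower (beyond the scatter).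

From the compounds shown here alone, what remains open is how far clearance responds to the group at this position, with only methoxy carrying a clearance figure there. Whether an ethoxy group or an amine on the same aromatic carbon would keep clearance at the level of compound 3 also remains unanswered.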